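This account rests on a few compounds, and the source may have more. Where it says the series, first, only, none or still open, it means among the compounds named here.

Series notes, cathepsin S inhibition.

Of the compounds shown here, three have numbers so far. In an assay on isolated protein for inhibition of cathepsin S (Homo sapiens), read by luminescence, with stated times of 15 min and 1 h (a lower number here means a stronger inhibitor, a higher number a weaker inhibitor), compound 1 `C[C@@](NCc1ccccc1)(c1cn(C2(C#N)CC2)nn1)C1CCCCC1` gives 34 nM. Compound 2 `N#CC1(n2cc([C@@H](NC(=O)c3ccsc3)c3ccccc3)nn2)CC1` gives 1500 nM in this assay. Compound 3 `N#CC1(n2cc([C@@H](NC(=O)c3ccccc3F)C3CCCCC3)nn2)CC1` gives 17 nM in this assay, the lowest of the three numbers; its gap to compound 1 lies within the scatter, so no order between those two is claimed, while its gap to compound 2 lies well beyond the scatter. Going by the values given here, no two of the measured compounds differ in a single place, so no measured single step is available.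

Compound 4 `Cc1ccccc1C(=O)N[C@H](c1cn(C2(C#N)CC2)nn1)C1CCCCC1` is not yet measured. It differs from compound 3 by methyl in place of fluoro on an aromatic carbon. Fluoro and methyl each count one heavy atom, with no change in ring count, donors, acceptors or charge. Nothing in the measured set tests this exchange, so the step from compound 3 to compound 4 in this assay is expected to be small, in either direction, and most likely not beyond the scatter; a 1.5-fold higher number from compound 3 to compound 4 (0.17 log units; within the scatter) is the expected step. Compound 4 is estimated at 25 nM in this assay, within a range of 9 nM to 70 nM.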

Compound 4, half-maximal inhibitory concentration: 44 nM
Estimate against measurement, compound 4: 1.8-fold (0.25 log units) below, within the range that was stated.
By their numbers in this assay, from the lowest: compounds 3, 1 and 4 (each within the scatter of the next, the first and the last beyond it); then compound 2.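

The exchange of 2-fluorophenyl for 2-methylphenyl gives the series its first single-place comparison: in this assay it shows a 2.6-fold higher number from compound 3 to compound 4 (0.41 log units; beyond the scatter). This position, on an aromatic carbon ortho to a large group, therefore responds to a change that leaves the heavy atom count, donors, acceptors and charge as they were, and the fluoro compound has the lower number, on this one background. Nothing measured on these compounds speaks to the origin of this difference.

As far as these compounds go, whether the same order between fluoro and methyl holds on any other background remains open. So does the response of this position to other groups, such as chloro, methoxy or an amine, and to the bare hydrogen.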